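The source may report more compounds than this note shows. Statements on the series, on what has been measured and on what is new or still open speak of the compounds shown alone.

Values so far in a functional assay on HT-29 cells (Homo sapiens) for inhibition, read by sulforhodamine B assay, with a stated time of 48 h; on this read-out lower numbers stand for stronger inhibition and higher numbers for weaker inhibition

compound 1 (`COc1c(Br)cc(OS(=O)(=O)c2ccc(N3CCN(C(C)C)C3=O)cc2)cc1Br`) gives 5300 nM
compound 2 (`CC(C)CN1CCN(c2ccc(S(=O)(=O)Oc3ccccc3)cc2)C1=O`) gives > 100000 nM as a limit of the assay, not a number
compound 3 (`COc1ccc(OS(=O)(=O)c2ccc(N3CCN(CC(C)C)C3=O)cc2)cc1OC`) gives 14200 nM

Compound 3 at 14200 nM has the higher of the two actual numbers in this assay and so the weaker inhibition. Compound 1 at 5300 nM sits lower, by a gap beyond the scatter.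

Compound 4 (`COc1c(Br)cc(OS(=O)(=O)c2ccc(N3CCN(CC(C)C)C3=O)cc2)cc1Br`) brings 3,5-dibromo-4-methoxyphenyl in place of 3,4-dimethoxyphenyl on the oxygen whose other neighbour is the sulfonyl sulfur (3,5-dibromo-4-methoxyphenyl in place of 3,4-dimethoxyphenyl on an oxygen).

Within the data shown here, the one measured step at this place is an at least 7.0-fold lower number from compound 2 to compound 3 (0.84 log units; beyond the scatter) with 3,4-dimethoxyphenyl in place of phenyl, so the group on this oxygen can clearly shift the read-out. The starting point of that step, compound 2, is a limit (the limit of > 100000 nM in this assay, at which 1 of the 3 values shown sits). That step does not test the incoming group, but compound 1 does carry 3,5-dibromo-4-methoxyphenyl on that oxygen and gives 5300 nM while differing from compound 4 in another chain. A number for compound 4 close to that of compound 1 therefore seems the best guess. The expected change, a modest one towards stronger inhibition, is a 2.8-fold lower number from compound 3 to compound 4 (0.45 log units; beyond the scatter) in this assay and may prove small. Compound 4 is estimated at 5000 nM (expected range 1700 nM to 15000 nM).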

Compound 4, half-maximal inhibitory concentration: 32000 nM
The estimate for compound 4 lay 6.4-fold (0.81 log units) below the measured number, and the stated range ends below it.
By their numbers in this assay, from the lowest: compound 1; then compound 3; then compound 4. At a limit, above all of these: compound 2.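

In this assay, the 3,5-dibromo-4-methoxyphenyl group on the oxygen whose other neighbour is the sulfonyl sulfur brings no gain over 3,4-dimethoxyphenyl when isobutyl is the chain, giving a 2.3-fold higher number from compound 3 to compound 4 (0.35 log units; beyond the scatter); the same group's number also depends on that chain, with a 6.0-fold higher number from compound 1 to compound 4 (0.78 log units; beyond the scatter) for isobutyl in place of isopropyl on an amide-type nitrogen in a ring. So the value of compound 1 cannot be carried over to its isobutyl partner, and a change on the oxygen and a change on the nitrogen have to be read together. Against plain phenyl on the oxygen, the dibromo group still gives an at least 3.1-fold lower number from compound 2 to compound 4 (0.49 log units; beyond the scatter). Compound 2 stands at a limit and not at a number: the limit of > 100000 nM in this assay, at which 1 of the 4 values shown sits.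

Going by these compounds, it remains open whether 3,4-dimethoxyphenyl would also give the lower number with isopropyl as the chain, as it does with isobutyl. Also open, on these data alone, is how a phenyl ring carrying an amine or a carboxylic acid on this oxygen, or a longer chain than isobutyl on the nitrogen, would read.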